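The compounds below may be only part of what the source reports. "The series", "measured", "known", "first", "only" and "open" are said of these compounds alone.

Measured compounds in a functional assay on HT-29 cells (Homo sapiens) for inhibition, read by sulforhodamine B assay, with a stated time of 48 h; on this read-out lower numbers stand for stronger inhibition of growth and higher numbers for weaker inhibition of growth:

Compound 3 `COc1cc(CNc2nc3cc(N)cc(N)c3nc2-c2ccccc2)cc(OC)c1OC` gives 8710 nM.
Compound 1 `Nc1cc(N)c2nc(-c3ccccc3)c(Sc3ccc(F)cc3)nc2c1` gives 17800 nM.
Compound 2 `Nc1cc(N)c2nc(-c3ccccc3)c(Oc3ccc(F)cc3)nc2c1` gives 22900 nM.

Compound 3 has the lowest number of the three in this assay, and its distance to compound 1, as to compound 2, lies beyond the scatter, so on these figures it is the strongest of the three. Compound 4 `COc1ccc(CNc2nc3cc(N)cc(N)c3nc2-c2ccccc2)cc1OC` differs from compound 3 by hydrogen in place of methoxy on an aromatic carbon. Within the data shown here, the one change followed step by step so far, a 1.3-fold higher number from compound 1 to compound 2 (0.11 log units; within the scatter), concerns a different part of the core and lies within the scatter, so it gives no guide for the removal of a methoxy group. Among the measured compounds shown here, no other pair of measured compounds speaks to this change. With nothing to point either way, the expected step for compound 4 in this assay, a 1.1-fold higher number from compound 3 to compound 4 (0.06 log units; within the scatter), is none beyond the scatter, and the estimate for compound 4 is 10000 nM, with a range from 4000 nM to 25000 nM.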

Compound 4, concentration for 50% growth inhibition: 1860 nM
For compound 4 the middle estimate is 5.4-fold (0.73 log units) above the measured one; the whole stated range lies above it.
By their numbers in this assay, from the lowest: compound 4; then compound 3; then compounds 1 and 2 (each within the scatter of the next).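

In this assay, hydrogen in place of methoxy gives a 4.7-fold lower number from compound 3 to compound 4 (0.67 log units; beyond the scatter), so this place on the six-membered aromatic ring of carbon only does affect the read-out, and the methoxy group there is not needed for growth inhibition. The one earlier step, a 1.3-fold higher number from compound 1 to compound 2 (0.11 log units; within the scatter), concerned another part of the core and stayed within the scatter, so this is the first change shown to move the number clearly, and it does so on the benzylic side group rather than at the core. No measurement given here explains why removing this methoxy group lowers the number.

The compounds shown leave open whether a different group at this place, such as a hydroxyl, an amine or a fluorine, would match hydrogen or differ from it. They also leave open what the remaining methoxy groups of compound 4 contribute.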